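This account rests on a few compounds, and the source may have more. Where it says the series, first, only, none or still open, it means among the compounds named here.

Working notes on the series.

Three members have been measured so far in a functional assay on cells for antagonist activity at C-X-C chemokine receptor type 4 (Homo sapiens), read by fluorescence and calcium flux, with stated times of 25 min and 90 s; on this read-out higher numbers stand for weaker inhibition and lower numbers for stronger inhibition. Compound 1 `c1cncc(CN(CCCCN(C[C@H]2Cc3ccccc3CN2)[C@H]2CCCc3cccnc32)Cc2cccnc2)c1` gives 471 nM. Compound 2 `c1cncc(CNCCCCN(C[C@H]2Cc3ccccc3CN2)[C@H]2CCCc3cccnc32)c1` gives 15.3 nM. Compound 3 `c1ccc(CNCCCCN(C[C@H]2Cc3ccccc3CN2)[C@H]2CCCc3cccnc32)cc1` gives 20.1 nM. Compound 2 carries the lowest of the three numbers: the step of a 31-fold lower number from compound 1 to compound 2 (1.49 log units; beyond the scatter) is large and well beyond the scatter, whereas the step of a 1.3-fold higher number from compound 2 to compound 3 (0.12 log units; within the scatter) lies within the scatter, so compounds 2 and 3 are not distinguished by this read-out.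

Compound 4 `c1ccc2c(c1)CN[C@@H](CN(CCCCNCC1CCNCC1)[C@H]1CCCc3cccnc31)C2` is not yet measured. Relative to compound 2 the change is piperidin-4-yl in place of pyridin-3-yl on a saturated chain carbon bound to an amine nitrogen. The step that bears on it most directly is a 1.3-fold higher number from compound 2 to compound 3 (0.12 log units; within the scatter), which also exchanges the group on that saturated chain carbon and moved the number only within the scatter. The step of a 31-fold lower number from compound 1 to compound 2 (1.49 log units; beyond the scatter) concerns a different place, the amine nitrogen, and gives no guidance here. Going by the values given here, no measured step covers a non-aromatic ring with a hydrogen-bond donor at this position, so the expectation rests on one step alone. For compound 4 in this assay the expected step is a 1.3-fold higher number from compound 2 to compound 4 (0.12 log units; within the scatter), that is, no change beyond the scatter. The estimate for compound 4 is therefore 20 nM, with a range from 6 nM to 70 nM.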

Compound 4, half-maximal inhibitory concentration: 36.5 nM
For compound 4 the middle estimate is 1.8-fold (0.26 log units) below the measured one; measured number inside the range.
By their numbers in this assay, from the lowest: compounds 2, 3 and 4 (each within the scatter of the next, the first and the last beyond it); then compound 1.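

In this assay, the place on a saturated chain carbon bound to an amine nitrogen now shows a ring exchange that passes the scatter: a 2.4-fold higher number from compound 2 to compound 4 (0.38 log units; beyond the scatter) is modest, so a non-aromatic ring with a hydrogen-bond donor can be told apart from pyridin-3-yl, though only narrowly. Against phenyl the same ring gives no such separation, as a 1.8-fold higher number from compound 3 to compound 4 (0.26 log units; within the scatter) stays within the scatter, so the series keeps activity in this assay with an aromatic or a non-aromatic six-membered ring at this place, and only the pair with pyridin-3-yl is resolved. No supporting data bear on why piperidin-4-yl differs from pyridin-3-yl here.

The exchange changes aromaticity and adds a hydrogen-bond donor at once, and the compounds shown cannot separate the two; cyclohexyl in this place would remove the aromatic ring without adding the donor, while piperidin-4-yl with a methyl group on its nitrogen would keep the non-aromatic ring and remove the donor. As far as these compounds go, whether a longer chain between the amine nitrogen and the piperidin-4-yl ring would change the number also remains open.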